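From an Aminoethyl Amide to a Hydroxyphenyl Amide

A few compounds are considered here, and "the series" means these few. Any claim that something is new, unique, unknown or untested is made for them only; others in the source may bear on it.

Three amides of a shared core have been measured in an in vitro assay on BTI-TN-5B1-4 cells for inhibition of Amine oxidase [flavin-containing] B (Homo sapiens), read by fluorescence; a higher number here means a weaker inhibitor, a lower number a stronger inhibitor. Compound 1 `CC(C)CNC(=O)c1cc2ccccc2oc1=O` gives 3270 nM, compound 2 `NCCNC(=O)c1cc2ccccc2oc1=O` gives 7680 nM, and compound 3 `CSc1ccc(NC(=O)c2cc3ccccc3oc2=O)cc1` gives 2840 nM. Compound 2 thus stands with the highest number of the set; compound 1 is its nearest neighbour and compound 3 lies furthest from it. Among the measured compounds shown here, the one single-point step here, a 2.3-fold higher number from compound 1 to compound 2 (0.37 log units; beyond the scatter), places the aminoethyl amide at the weak end.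

Compound 4 `O=C(Nc1ccc(O)cc1)c1cc2ccccc2oc1=O` is not yet measured. It differs from compound 2 in one place: 4-hydroxyphenyl in place of 2-aminoethyl on an amide-type nitrogen. For the measured compounds named here, no measured step covers this exact exchange. Two pieces of evidence bear on it: the step of a 2.3-fold higher number from compound 1 to compound 2 (0.37 log units; beyond the scatter) shows that leaving the 2-aminoethyl group behind has already been worth a modest gain, and compound 3, the only other amide carrying an aromatic ring on the nitrogen, gives 2840 nM, lower than compound 2. A modest move toward a lower number in this assay is therefore expected, and the expected step is a 2.7-fold lower number from compound 2 to compound 4 (0.44 log units; beyond the scatter). Compound 4 is estimated at 2800 nM, with a range from 1200 nM to 6500 nM.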

Compound 4, half-maximal inhibitory concentration: 800 nM
Estimate against measurement, compound 4: 3.5-fold (0.54 log units) above; the measured number lies below the stated range.
By their numbers in this assay, from the lowest: compound 4; then compounds 3 and 1 (each within the scatter of the next); then compound 2.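

In this assay, among the compounds shown here, the group on the amide-type nitrogen proves to matter more than the earlier compounds showed: a 9.6-fold lower number from compound 2 to compound 4 (0.98 log units; beyond the scatter) is the largest step seen so far, and a 4.1-fold lower number from compound 1 to compound 4 (0.61 log units; beyond the scatter) shows that the 4-hydroxyphenyl group also outperforms isobutyl at this place. An aromatic ring on that nitrogen does not account for the gain alone, since a 3.6-fold lower number from compound 3 to compound 4 (0.55 log units; beyond the scatter) with hydroxy in place of methylsulfanyl on an aromatic carbon, so the group carried by the ring counts as well. Nothing available explains these differences.

The compounds shown leave open whether hydroxy itself is needed, or whether an unsubstituted phenyl ring, a methoxy group or an amine on the ring would give a similar number. On these data alone, how far the gain extends to a longer chain between the amide-type nitrogen and the 4-hydroxyphenyl ring also remains unknown.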